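A Fluorine Added to the Isopropyl Group

A few compounds are considered here, and "the series" means these few. Any claim that something is new, unique, unknown or untested is made for them only; others in the source may bear on it.

In a functional assay on isolated protein for inhibition of Glucose-dependent insulinotropic receptor (Rattus norvegicus), read by HTRF and cAMP accumulation (on this read-out higher numbers stand for an effect only at larger amounts of compound and lower numbers for an effect already at smaller amounts), compound 3 `Cc1nc(S(C)(=O)=O)ccc1Oc1ncnc(OC2CCN(C(=O)c3noc(C(C)C)n3)CC2)c1F` gives 176 nM, the second highest of the three numbers measured. Compound 1 `Cc1nc(S(C)(=O)=O)ccc1Oc1ncnc(OC2CCN(C(=O)SC3CCC3)CC2)c1F` gives 77.4 nM, and compound 2 `Cc1nc(S(C)(=O)=O)ccc1Oc1ncnc(OC2CCN(C(=S)OC(C)C)CC2)c1F` gives 1050 nM. Every measured step alters the group on the amine nitrogen in a ring: a 14-fold higher number from compound 1 to compound 2 (1.13 log units; beyond the scatter), a 2.3-fold higher number from compound 1 to compound 3 (0.36 log units; beyond the scatter) and a 6.0-fold lower number from compound 2 to compound 3 (0.78 log units; beyond the scatter). Compound 4 `Cc1nc(S(C)(=O)=O)ccc1Oc1ncnc(OC2CCN(C(=O)c3noc(C(C)(C)F)n3)CC2)c1F` differs from compound 3 only by fluoro in place of hydrogen on a saturated chain carbon bound to an aromatic carbon and two saturated chain carbons. No measured step touches this position, so nothing among these compounds shows how such a small change shifts the number in this assay, and the step of a 1.0-fold higher number from compound 3 to compound 4 (0.01 log units; within the scatter) is expected to stay within the usual scatter. Compound 4 is therefore estimated at 180 nM, with a range from 80 nM to 400 nM.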

Compound 4, half-maximal effective concentration: 103 nM
Beside the measured number, compound 4's estimate is 1.7-fold (0.24 log units) above it; low and high end bracket the measured number.
By their numbers in this assay, from the lowest: compounds 1, 4 and 3 (each within the scatter of the next, the first and the last beyond it); then compound 2.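

In this assay this is the first change shown at this position: the step from isopropyl to 1-fluoro-1-methylethyl gives a 1.7-fold lower number from compound 3 to compound 4 (0.23 log units; within the scatter) and so does not move the number beyond the scatter. With the fluoro in place, a 1.3-fold higher number from compound 1 to compound 4 (0.12 log units; within the scatter) also stays within the scatter, whereas a 10-fold lower number from compound 2 to compound 4 (1.01 log units; beyond the scatter) lies well beyond it. Nothing available explains why the fluoro has so little effect.

Still open, on these data alone, is whether a hydroxyl or an amine on this same carbon would leave the number equally unchanged. As far as these compounds go, a trifluoromethyl or a tert-butyl in place of the whole group remains equally open.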